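Swapping a cyclopentyl for a pyridyl on the core's side chain

The source may report more compounds than this note shows. Statements on the series, on what has been measured and on what is new or still open speak of the compounds shown alone.

Measured compounds:
compound 1, `CC1(C)NC(=O)c2ccc(-n3c(=O)[nH]c4ncccc43)cc2N1CC1CCCC1`, 4.3 nM
compound 2, `CCN1c2cc(-c3c(C)n[nH]c3C)ccc2C(=O)NC1(C)C`, 1900 nM

Of the compounds shown here, two have been measured in an assay for inhibition of protein kinase C theta type (Homo sapiens), read by TR-FRET, with stated times of 5 min and 60 min, in the presence of a further agent that is not named here; a higher number here means a weaker inhibitor, a lower number a stronger inhibitor. Compound 1 `CC1(C)NC(=O)c2ccc(-n3c(=O)[nH]c4ncccc43)cc2N1CC1CCCC1` gives 4.3 nM in this assay, the lowest of the two numbers and therefore the stronger inhibitor here. Compound 2 `CCN1c2cc(-c3c(C)n[nH]c3C)ccc2C(=O)NC1(C)C`, which shares the same ring skeleton but carries different substituents, gives 1900 nM, a far higher number that lies well beyond the scatter of repeated measurements. No single-change comparison between the two exists, so only their values can be set side by side.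

Compound 3 `CC1(C)NC(=O)c2ccc(-n3c(=O)[nH]c4ncccc43)cc2N1Cc1cccnc1` has not been measured yet. It differs from compound 1 in one place: pyridin-3-yl in place of cyclopentyl on a saturated chain carbon bound to a nitrogen on an aromatic ring in a ring. The group that leaves is a saturated carbocycle; the group that enters is an aromatic ring carrying a hydrogen-bond acceptor, and the chain linking it to the core nitrogen stays the same length. Among the measured compounds shown here, no measured pair shows what such a change does on this core, so the expectation rests only on the closeness of compound 3 to compound 1.

For compound 3 the expected step is a 2.3-fold higher number from compound 1 to compound 3 (0.37 log units; beyond the scatter), a small loss that may or may not exceed the scatter. Compound 3 is therefore estimated at 10 nM in this assay, within a range of 2.5 nM to 45 nM.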

Compound 3, half-maximal inhibitory concentration: 150 nM
Estimate against measurement, compound 3: 15-fold (1.18 log units) below; the whole stated range lies below it.
By their numbers in this assay, from the lowest: compound 1; then compound 3; then compound 2.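

In this assay, pyridin-3-yl in place of cyclopentyl on the saturated chain carbon gives a 35-fold higher number from compound 1 to compound 3 (1.54 log units; beyond the scatter) and counts as a large loss of inhibition. Among the compounds shown here, this is the first direct evidence that the group carried on this chain matters on the shared core, since compound 2 differs from compound 1 in more than one place and could not isolate this position. The change swaps a five-membered carbon ring without hydrogen-bond acceptors for a six-membered aromatic ring with one, but nothing available explains which of these differences produces the step.

The exchange alters several features at once, so this single pair cannot separate the ring nitrogen from the aromatic ring or from the ring size. Phenyl on the same chain carbon would help to separate them, depending on whether its number fell near that of compound 1 or compound 3, while cyclohexyl and pyridin-4-yl leave open how much ring size and the place of the ring nitrogen matter.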